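The compounds below may be only part of what the source reports. "The series", "measured", "known", "first", "only" and "open" are said of these compounds alone.

Compound 1 `N#CC1=C(N)Oc2c(c3nc4ccccc4nc3c3ccccc23)C12C(=O)N(Cc1cnnn1-c1ccccc1Br)c1ccccc12` gives > 50000 nM in a functional assay on A549 cells (Homo sapiens) for antiproliferative activity, read by MTT assay, with a stated time of 48 h (a higher number here means a weaker inhibitor, a lower number a stronger inhibitor), a limit of the assay.
Compound 2 `CC(=O)Nc1ccc(-n2nncc2CN2C(=O)C3(C(C#N)=C(N)Oc4c3c3nc5ccccc5nc3c3ccccc43)c3ccccc32)cc1` gives > 50000 nM, again a limit.
Compound 3 `N#CC1=C(N)Oc2c(c3nc4ccccc4nc3c3ccccc23)C12C(=O)N(Cc1cnnn1-c1cccc(S(N)(=O)=O)c1)c1ccccc12` gives 44200 nM.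

Compound 1 thus stands only at a limit, and the same holds for one further value shown (the limit of > 50000 nM in this assay, at which 2 of the 3 values shown sit). Compound 4 `N#CC1=C(N)Oc2c(c3nc4ccccc4nc3c3ccccc23)C12C(=O)N(Cc1cnnn1-c1ccc(F)c(Cl)c1)c1ccccc12` differs from compound 1 by 3-chloro-4-fluorophenyl in place of 2-bromophenyl on an aromatic nitrogen. Two measured steps change the same group on the shared core: a step that the two limits leave unreadable from compound 1 to compound 2 and an at least 1.1-fold lower number from compound 1 to compound 3 (0.05 log units; that floor lies within the scatter), with an at least 1.1-fold lower number from compound 2 to compound 3 (0.05 log units; that floor lies within the scatter) between the other two. None of these steps is readable beyond the scatter, so no step beyond the scatter is expected for compound 4 in this assay. Compound 4 is therefore estimated at 50000 nM, between 25000 nM and 100000 nM, which means an expected step of a number no higher from compound 1 to compound 4 (the limit leaves the size open), and the assay may well report only a limit again.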

Compound 4, half-maximal inhibitory concentration: > 50000 nM
Compound 4 was reported as a limit; the forecaster's own chance of this, stated with the estimate: 60%; the middle value lies on the limit itself.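

In this assay, compound 4 also stands only at a limit, so a phenyl bearing both chlorine and fluorine at this position joins 2-bromophenyl and 4-acetamidophenyl there, and its steps from compound 1 and compound 2 cannot be read. For the compounds shown here, the one step with a floor is an at least 1.1-fold higher number from compound 3 to compound 4 (0.05 log units; that floor lies within the scatter) and so does not separate the two compounds. Comparison at this position stays largely closed: the limit of > 50000 nM in this assay, at which 3 of the 4 values shown sit.

Going by these compounds, it remains open whether an amine or a carboxylic acid on this phenyl would give a readable value. The same holds for a longer alkyl chain in place of the phenyl.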